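A few compounds are considered here, and "the series" means these few. Any claim that something is new, unique, unknown or untested is made for them only; others in the source may bear on it.

Measured compounds:
compound 1 `N#Cc1ccc(Nc2nc(Oc3c(Br)cc(Br)cc3Br)c3ccccc3n2)cc1` – 58000 nM
compound 2 `COc1cc(C#N)cc(OC)c1Oc1nc(Nc2ccc(C#N)cc2)nc2ccccc12` – 194000 nM

In an ADME assay on MT4 cells (Homo sapiens) for cytotoxicity, read by MTT assay, with a stated time of 4 days (a lower number here means that less compound is tolerated, a higher number that more compound is tolerated), compound 1 gives 58000 nM, the lower of the two numbers, and the gap to compound 2, which gives 194000 nM, lies beyond the scatter. Compound 3 `COc1ccc(Oc2nc(Nc3ccc(C#N)cc3)nc3ccccc23)cc1` is not yet measured in this assay. It differs from compound 1 by 4-methoxyphenyl in place of 2,4,6-tribromophenyl on an oxygen on an aromatic ring. Compound 3 is expected to be tolerated somewhat better than compound 1, a step of a 2.1-fold higher number from compound 1 to compound 3 (0.32 log units; beyond the scatter) in this assay, which would move it toward compound 2. The estimated value for compound 3 is 120000 nM, within a range from 50000 nM to 300000 nM.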

Compound 3, half-maximal cytotoxic concentration: 340000 nM
Estimate against measurement, compound 3: 2.8-fold (0.45 log units) below; measured number outside the range, above it.
By their numbers in this assay, from the lowest: compound 1; then compounds 2 and 3 (each within the scatter of the next).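

Swapping the group on this oxygen is enough to move the number in this assay: 4-methoxyphenyl in place of 2,4,6-tribromophenyl gives a 5.9-fold higher number from compound 1 to compound 3 (0.77 log units; beyond the scatter) with the rest of the molecule unchanged. Within the data shown here, this is the first step read across a single change at this position, and it shows that the tribromophenyl compound is the less tolerated of the pair. Nothing available explains the size of this step.

The compounds shown leave open whether the step follows from losing the bromines or from gaining the methoxy group. They also leave open how an amine or a carboxylic acid on this ring would fare in this assay.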